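Lengthening the amine chain in two related tracheal relaxants

The source may hold more compounds than are shown below. What is called first, only, known or untested is meant among the compounds shown, and "the series" means these compounds.

Compound 1, `CCN1CC[C@@]2(OC)OC(N)=C(C#N)[C@@H](c3ccc4ccccc4c3)[C@@H]2C1`, gives 28300 nM in a functional assay on trachea (Cavia porcellus); a higher number here means a weaker inhibitor, a lower number a stronger inhibitor.
Compound 2, `CCCN1CC[C@@]2(OC)OC(N)=C(C#N)[C@@H](c3ccc4ccccc4c3)[C@@H]2C1`, gives 37100 nM in this assay.
Compound 3, `CCN1CC[C@@]2(OC)OC(N)=C(C#N)[C@@H](c3ccc(OC)cc3)[C@@H]2C1`, gives 25500 nM in this assay.

All three are weak inhibitors in this assay, and their numbers sit close together. Compound 2 differs from compound 1 by one change, (methyl in place of hydrogen on a saturated chain carbon, two bonds along the chain from an amine nitrogen in a ring). That change produced a 1.3-fold higher number from compound 1 to compound 2 (0.12 log units; within the scatter), so the longer chain left the read-out essentially where it was.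

Compound 3 carries a different aromatic group on the same saturated core than compound 1; the difference between the two cores is not broken down here. Its value and that of compound 1 lie within the scatter of each other, so the two cannot be told apart on this evidence.

Compound 4, `CCCN1CC[C@@]2(OC)OC(N)=C(C#N)[C@@H](c3ccc(OC)cc3)[C@@H]2C1`, has not yet been measured. It stands to compound 3 exactly as compound 2 stands to compound 1: it differs by methyl in place of hydrogen on a saturated chain carbon, two bonds along the chain from an amine nitrogen in a ring, the same change at the same place. Among the measured compounds shown here, only one earlier example of this change is available, and it moved the read-out by less than the usual scatter. On that basis the step from compound 3 to compound 4 is expected to be small, about a 1.3-fold higher number from compound 3 to compound 4 (0.11 log units; within the scatter), resting on the earlier result a 1.3-fold higher number from compound 1 to compound 2 (0.12 log units; within the scatter).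

Compound 4 is therefore estimated to give 33000 nM in this assay, most likely falling between 15000 nM and 72000 nM.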

Compound 4, half-maximal inhibitory concentration: 21300 nM
Compound 4: the middle estimate sits 1.5-fold (0.19 log units) above what was measured; measured number inside the range.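

On the core of compound 3, the same ethyl to propyl difference gave a 1.2-fold lower number from compound 3 to compound 4 (0.08 log units; within the scatter) in this assay, a step too small to be told from the ordinary variation between repeated measurements. Set beside the earlier step on the core of compound 1, the new step gives no sign that the result of this change depends on the core: the same change on two cores in this assay, a 1.3-fold higher number (0.12 log units; within the scatter) from compound 1 to compound 2 and a 1.2-fold lower number (0.08 log units; within the scatter) from compound 3 to compound 4, 1.6-fold (0.20 log units) apart, within the scatter of two such steps So, across these two pairs, the change can be carried from one core to the other without a detectable effect on the read-out, but two pairs of weak inhibitors cannot show that this holds for other cores, and a small real effect on either core could remain hidden in the scatter.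

The compounds shown leave open whether a longer chain, such as butyl, or a chain carrying a phenyl ring, as in benzyl, on the amine nitrogen would also leave the read-out unchanged. They also leave open whether the same holds with other aromatic groups on the shared core, such as a phenyl ring bearing a chlorine atom.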